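The source may report more compounds than this note shows. Statements on the series, on what has been measured and on what is new or still open speak of the compounds shown alone.

Measured in a functional assay on MCF7 cells (Homo sapiens) for inhibition, read by fluorescence, with a stated time of 72 h; on this read-out higher numbers stand for weaker inhibition and lower numbers for stronger inhibition:
- compound 1 `CN(C)c1nc(N)nc2c1ncn2CCN=[N+]=[N-]`: > 100000 nM, a limit of the assay and not a number
- compound 2 `CC(C)n1cnc2c(NC(=N)N)nc(NCCO)nc21`: 12400 nM

Within the data shown here, compound 2 carries the only actual number so far. Compound 3 `CC(C)n1cnc2c(NC(=N)N)nc(NCCCCCCO)nc21` extends the chain of compound 2, with 4-hydroxybutyl in place of hydroxy, on a saturated chain carbon, two bonds along the chain from a nitrogen on an aromatic ring (4-hydroxybutyl in place of hydroxy on a saturated chain carbon, two bonds along the chain from a nitrogen on an aromatic ring). Among the measured compounds shown here, no measured step bears on this change, so the expectation is tentative. A modest shift towards stronger inhibition in this assay is expected, near the edge of the usual scatter, a 2.1-fold lower number from compound 2 to compound 3 (0.32 log units; beyond the scatter). For compound 3 the estimated value is 6000 nM, with an expected range of 1800 nM to 20000 nM.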

Compound 3, half-maximal inhibitory concentration: 5200 nM
Compound 3: middle estimate off by 1.2-fold (0.06 log units), on the high side, and the stated range covers the measured number.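

Replacing (2-hydroxyethyl)amino with (6-hydroxyhexyl)amino gives a 2.4-fold lower number from compound 2 to compound 3 (0.38 log units; beyond the scatter) in this assay, so this position accepts a longer chain ending in hydroxy with a modest gain in inhibition. Among these compounds, this is the first comparison between two actual numbers, as the remaining value is a limit of the assay: the limit of > 100000 nM in this assay, at which 1 of the 3 values shown sits.

Two chain lengths cannot show whether inhibition changes steadily with length or whether a still longer chain goes further. Also open, on these data alone, is whether the terminal hydroxy matters, compared with a plain hexyl chain or a chain ending in an amine or a carboxylic acid.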